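Branching the Ester Chain in a Thromboxane Synthase Series

The compounds below may be only part of what the source reports. "The series", "measured", "known", "first", "only" and "open" are said of these compounds alone.

Compound 1, `COc1ccc(COCC(Cn2ccnc2)OCCCCC(=O)O)cc1`, gives 730 nM in a functional assay on a cell-free system (plasma) for inhibition of Thromboxane-A synthase (Homo sapiens); a lower number here means a stronger inhibitor, a higher number a weaker inhibitor.
Compound 2, `COc1ccc(COCC(Cn2ccnc2)OCCCCCC(=O)O)cc1`, gives 560 nM in this assay.
Compound 3, `CCOC(=O)CCCCCCOC(COCc1ccc(OC)cc1)Cn1ccnc1`, gives 4000 nM in this assay.

Compound 3 stands with the highest number of the three, a weaker inhibitor than both acids. Compound 4, `CCOC(=O)C(C)(C)CCCCOC(COCc1ccc(OC)cc1)Cn1ccnc1`, differs from compound 3 by 1-(ethoxycarbonyl)-1-methylethyl in place of 2-(ethoxycarbonyl)ethyl on a saturated chain carbon, four bonds along the chain from an oxygen on a saturated carbon. The measured steps bearing on the ester end, a 5.5-fold higher number from compound 1 to compound 3 (0.74 log units; beyond the scatter) and a 7.1-fold higher number from compound 2 to compound 3 (0.85 log units; beyond the scatter), both exchange an acid for an ester; neither changes the carbon chain around an ester. For the measured compounds named here, no measured pair shows what added branching does, so compound 4 is expected to stay close to compound 3, a step of no change at the digits printed from compound 3 to compound 4 (within the scatter) that may well lie within the scatter. Compound 4 is estimated at 4000 nM, expected between 1500 nM and 11000 nM.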

Compound 4, half-maximal inhibitory concentration: 17600 nM
Compound 4: the middle estimate sits 4.4-fold (0.64 log units) below what was measured, outside the stated range (above it).
By their numbers in this assay, from the lowest: compounds 2 and 1 (each within the scatter of the next); then compound 3; then compound 4.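

In this assay the carbon chain around the ester matters: 1-(ethoxycarbonyl)-1-methylethyl in place of 2-(ethoxycarbonyl)ethyl gives a 4.4-fold higher number from compound 3 to compound 4 (0.64 log units; beyond the scatter) and so weakens inhibition further. Set against the acids, the branched ester shows a 31-fold higher number from compound 2 to compound 4 (1.50 log units; beyond the scatter) and a 24-fold higher number from compound 1 to compound 4 (1.38 log units; beyond the scatter) as large steps, whereas the unbranched ester showed only modest ones. Nothing available explains this loss.

Open, as far as these compounds go, is whether the matching acid, 1-carboxy-1-methylethyl, would regain what the branched ester loses. Also open, from the compounds shown here alone, is whether 1-(ethoxycarbonyl)ethyl, with a single methyl branch, would already weaken inhibition.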